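Aryl swap on the amide-type nitrogen: leaving the nitro group

The source may report more compounds than this note shows. Statements on the series, on what has been measured and on what is new or still open speak of the compounds shown alone.

Measured in a functional assay on RT-112 cells (Homo sapiens) for antiproliferative activity, read by MTT assay, with a stated time of 72 h; on this read-out higher numbers stand for weaker inhibition of growth and lower numbers for stronger inhibition of growth:
compound 1 `COc1cc(NC(=O)Nc2cccc3c(Nc4cc(OC)cc(OC)c4)ncnc23)cc(OC)c1` gives 366 nM
compound 2 `COc1cc(Nc2ncnc3c(NC(=O)Nc4cc(F)cc(F)c4)cccc23)cc(OC)c1` gives 2630 nM
compound 3 `COc1cc(Nc2ncnc3c(NC(=O)Nc4ccc([N+](=O)[O-])cc4)cccc23)cc(OC)c1` gives > 20000 nM (a limit)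

Compound 3 lies at the weak end of these three, with steps to both others beyond the scatter. Its value, > 20000 nM, is a limit and not a number.

Compound 4 `COc1cc(Nc2ncnc3c(NC(=O)Nc4ccc(Cl)cc4)cccc23)cc(OC)c1` carries chloro in place of nitro on an aromatic carbon, para to a large group (chloro in place of nitro on an aromatic carbon). Going by the values given here, no measured step makes this exact exchange. The nearest evidence is the aryl group on the amide-type nitrogen, where an at least 7.6-fold higher number from compound 2 to compound 3 (0.88 log units; beyond the scatter) and an at least 54-fold higher number from compound 1 to compound 3 (1.73 log units; beyond the scatter). Among the aryl groups, a 7.2-fold higher number from compound 1 to compound 2 (0.86 log units; beyond the scatter). Compound 4 is therefore expected to fall closer to compound 2, with its 3,5-difluorophenyl group, than to compound 3, and not to reach compound 1.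

In this assay, a modest or larger move to a lower number is expected, with the estimated step being an at least 5.0-fold lower number from compound 3 to compound 4 (0.69 log units; beyond the scatter).

The estimate for compound 4 is 4000 nM, with an expected range of 1200 nM to 15000 nM.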

Compound 4, concentration for 50% growth inhibition: 2490 nM
Estimate against measurement, compound 4: 1.6-fold (0.21 log units) above; the range from low to high includes it.
By their numbers in this assay, from the lowest: compound 1; then compounds 4 and 2 (each within the scatter of the next). At a limit, above all of these: compound 3.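

Chloro in place of nitro, para to a large group, brings this aryl position back to a measured value: an at least 8.0-fold lower number from compound 3 to compound 4 (0.90 log units; beyond the scatter). Compound 3 stands at a limit and not a number, so this step gives only a floor: the limit of > 20000 nM in this assay, at which 1 of the 4 values shown sits. The 4-chlorophenyl and 3,5-difluorophenyl groups do not separate, with a 1.1-fold lower number from compound 2 to compound 4 (0.02 log units; within the scatter), whereas the 3,5-dimethoxyphenyl group keeps its lead, with a 6.8-fold higher number from compound 1 to compound 4 (0.83 log units; beyond the scatter).

Open, as far as these compounds go, is whether an amine or a nitrile at the same place would track chloro or nitro. Also open, from the compounds shown here alone, is whether the lead of the 3,5-dimethoxyphenyl group rests on the methoxy groups themselves or on where they sit, since no aryl group here carries a single methoxy.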